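From 3-methylphenyl to 4-methoxyphenyl on the shared core

The source may hold more compounds than are shown below. What is called first, only, known or untested is meant among the compounds shown, and "the series" means these compounds.

In a functional assay on A549 cells (Homo sapiens) for antiproliferative activity, read by MTT assay, with a stated time of 48 h (on this read-out higher numbers stand for weaker inhibition and lower numbers for stronger inhibition), compound 1 (`Oc1ccc2ccccc2c1C(Nc1nc2ccccc2s1)c1cn(-c2ccccc2)nc1-c1ccccc1`) gives 36200 nM and compound 2 (`COc1cccc(-c2nn(-c3ccccc3)cc2C(Nc2nc3ccccc3s2)c2c(O)ccc3ccccc23)c1`) gives 24800 nM while compound 3 (`Cc1cccc(-c2nn(-c3ccccc3)cc2C(Nc2nc3ccccc3s2)c2c(O)ccc3ccccc23)c1`) gives 18500 nM in the same test. Compound 3 thus sits level with the other two, as neither of its steps to them leaves the scatter.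

Compound 4 (`COc1ccc(-c2nn(-c3ccccc3)cc2C(Nc2nc3ccccc3s2)c2c(O)ccc3ccccc23)cc1`) differs from compound 3 on an aromatic carbon of a five-membered aromatic ring with 2 nitrogen, next to the ring nitrogen. There 4-methoxyphenyl in place of 3-methylphenyl on an aromatic carbon puts 4-methoxyphenyl in place of 3-methylphenyl.

Within the data shown here, three measured steps bear on this change. Methoxy in place of hydrogen on an aromatic carbon gives a 1.5-fold lower number from compound 1 to compound 2 (0.16 log units; within the scatter) and methyl in place of hydrogen gives a 2.0-fold lower number from compound 1 to compound 3 (0.29 log units; within the scatter) while methyl in place of methoxy gives a 1.3-fold lower number from compound 2 to compound 3 (0.13 log units; within the scatter) and all three stay within the scatter. Among the measured compounds shown here, no measured compound carries the 4-methoxyphenyl group itself, so these steps are only a partial guide.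

No change beyond the scatter is expected, and the estimated step of a 1.2-fold higher number from compound 3 to compound 4 (0.09 log units; within the scatter) is correspondingly small. For compound 4 the estimated value is 23000 nM with an expected range from 11000 nM to 48000 nM on this read-out.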

Compound 4, half-maximal inhibitory concentration: 26200 nM
Compound 4: the middle estimate sits 1.1-fold (0.06 log units) below what was measured, and the stated range covers the measured number.
By their numbers in this assay, from the lowest: compounds 3, 2, 4 and 1 (each within the scatter of the next).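

Among these compounds, at this aromatic carbon of the five-membered aromatic ring with 2 nitrogen, the 4-methoxyphenyl group is now seen for the first time, and in this assay it cannot be told apart from the 3-methylphenyl group, with a 1.4-fold higher number from compound 3 to compound 4 (0.15 log units; within the scatter). The earlier compounds shown here held no pair in which the methoxy group alone changes its place on the phenyl ring, and 4-methoxyphenyl in place of 3-methoxyphenyl now gives a 1.1-fold higher number from compound 2 to compound 4 (0.02 log units; within the scatter), while the comparison with the unsubstituted phenyl gives a 1.4-fold lower number from compound 1 to compound 4 (0.14 log units; within the scatter), so neither the presence nor the place of the methoxy group separates these compounds in this test. No accompanying measurement is available to explain these numbers.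

The compounds shown carry only a plain phenyl ring or one bearing methyl or methoxy at this carbon, so it remains open whether an amine, a carboxylic acid or a longer chain on that ring would move the number beyond the scatter. As far as these compounds go, it also remains open whether any change to the phenyl group on the ring nitrogen would do so.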